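This account rests on a few compounds, and the source may have more. Where it says the series, first, only, none or still open, it means among the compounds named here.

Compound 1 `CC(C)(C)c1ccc(CNC(=O)NCCCCl)cc1` and compound 3 `CC(C)(C)c1ccc(CNC(=O)NC(=O)CCl)cc1` share a core and differ in one place, and in a functional assay on MCF7 cells (Homo sapiens) for antiproliferative activity, with a stated time of 48 h (on this read-out lower numbers stand for stronger inhibition and higher numbers for weaker inhibition), compound 1 gives 17000 nM while compound 3 gives 2800 nM. The change between them is (chloromethyl)carbonyl in place of 3-chloropropyl on an amide-type nitrogen, and it made the step of a 6.1-fold lower number from compound 1 to compound 3 (0.78 log units; beyond the scatter).

Compound 2 `CCCCCc1cccc(NC(=O)NCCCCl)c1` carries a different core; how its core differs from that of compound 1 is not broken down here. In this assay compound 2 gives 26000 nM, a number within the scatter of that of compound 1 and clearly higher than that of compound 3.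

Compound 4 `CCCCCc1cccc(NC(=O)NC(=O)CCl)c1` has not yet been measured. It differs from compound 2 by (chloromethyl)carbonyl in place of 3-chloropropyl on an amide-type nitrogen, the same change that turned compound 1 into compound 3, at the same kind of place. The expected step from compound 2 to compound 4 in this assay is a 6.0-fold lower number from compound 2 to compound 4 (0.78 log units; beyond the scatter), which rests on the earlier step of a 6.1-fold lower number from compound 1 to compound 3 (0.78 log units; beyond the scatter) and on the starting value of compound 2 at 26000 nM. On that basis compound 4 is estimated at 4300 nM, with a range from 1800 nM to 11000 nM.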

Compound 4, half-maximal inhibitory concentration: 8300 nM
The estimate for compound 4 lay 1.9-fold (0.29 log units) below the measured number, within the range that was stated.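

On the core of compound 2, putting (chloromethyl)carbonyl in place of 3-chloropropyl on an amide-type nitrogen gave in this assay a 3.1-fold lower number from compound 2 to compound 4 (0.50 log units; beyond the scatter), and set beside the step on the core of compound 1 the result reads: the same change on two cores in this assay, a 6.1-fold lower number (0.78 log units; beyond the scatter) from compound 1 to compound 3 and a 3.1-fold lower number (0.50 log units; beyond the scatter) from compound 2 to compound 4, 1.9-fold (0.29 log units) apart, within the scatter of two such steps. Across these two cores, then, the change carried over in direction, and the two sizes cannot be told apart. Two pairs do not show that it would carry to any further core in the series, and they do not show why the number falls.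

The compounds shown leave open whether the lower number goes with the carbonyl or with the chlorine, since a plain acetyl group, a propyl chain or a bromoacetyl group on the amide-type nitrogen stands outside them. Also open, going by these compounds, is how a longer chain ending in chlorine would behave on either core.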